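From 2,5-difluorophenyl to 2-methoxyphenyl: notes on protein binding

This account rests on a few compounds, and the source may have more. Where it says the series, first, only, none or still open, it means among the compounds named here.

Of the compounds shown here, two have been read so far in an ADME assay on a cell-free system (plasma, Mus musculus) for protein binding, on the shared core. Compound 1 (`OC[C@@H]1[C@@H](O)[C@H](O)[C@@H](O)CN1CCCCCCOc1cc(F)ccc1F`) gives 77% and compound 2 (`OC[C@@H]1[C@@H](O)[C@H](O)[C@@H](O)CN1CCCCCCOc1cccc(C(F)(F)F)c1`) gives 92% on the same read-out. Compound 1 therefore has the larger unbound fraction of the two, and the gap to compound 2 lies beyond the usual scatter.

Compound 3 (`COc1ccccc1OCCCCCCN1C[C@H](O)[C@@H](O)[C@H](O)[C@H]1CO`) is still unmeasured. It carries 2-methoxyphenyl in place of 2,5-difluorophenyl on an oxygen on a saturated carbon.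

Going by the values given here, no two measured compounds differ in one place only, so the series offers no direct measure of this exchange. The expectation therefore starts from compound 1 at 77% as its nearest anchor. A small step is expected, staying within the scatter and leaning weakly towards more free compound. The estimated move is a 1.2-fold higher unbound fraction from compound 1 to compound 3 (0.07 log units; within the scatter) in this assay and the direction remains uncertain. In this assay the estimate for compound 3 is 73% with an expected range from 58% to 86% for a single measurement.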

Compound 3, plasma protein binding in the plasma assay: 69%
Beside the measured number, compound 3's estimate is 1.1-fold (0.06 log units) (unbound fraction) below it; measured number inside the range.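

In the plasma assay the series now has its first one-place step at this position, and 2-methoxyphenyl in place of 2,5-difluorophenyl on an oxygen on a saturated carbon gives a 1.3-fold higher unbound fraction from compound 1 to compound 3 (0.13 log units; within the scatter), so the two groups cannot be told apart on this read-out. In a physicochemical assay for solubility, in phosphate buffer, at pH 4 (a lower number here means a less soluble compound, a higher number a more soluble compound), the same exchange gives a 1.0-fold lower number from compound 1 to compound 3 (0.01 log units; within the scatter), and here too the two groups cannot be told apart, with compound 1 at 296000 nM and compound 3 at 286000 nM in the same range. Both groups hold the same number of heavy atoms, yet the entering group counts one hydrogen-bond acceptor and the leaving group none, and no measurement at hand bears on why the two groups read alike.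

Still open, from the compounds shown here alone, is whether an amine or a carboxylic acid on the aromatic ring, in place of these neutral groups, would give a step beyond the scatter in the plasma assay on the shared core. Going by these compounds, a longer chain between the core and the oxygen is equally open, as is whether the exchange seen here would read the same way on such a chain.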